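Methyl on the benzothiazol-2-yl group: an expected step

This account rests on a few compounds, and the source may have more. Where it says the series, first, only, none or still open, it means among the compounds named here.

Measured compounds:
compound 1 `O=C(Nc1nc2ccccc2s1)c1cn(-c2ccccc2)nc1-c1ccccc1`: 10400 nM
compound 2 `COc1ccc(-c2nn(-c3ccccc3)cc2C(=O)Nc2nc3ccccc3s2)cc1`: 6670 nM

Both compounds were tested in a functional assay on PC-3 cells (Homo sapiens) for cytotoxicity, read by MTT assay, with a stated time of 72 h; on this read-out higher numbers stand for weaker inhibition and lower numbers for stronger inhibition. In this assay compound 1 gives 10400 nM and compound 2 gives 6670 nM. The two numbers lie within the scatter of each other: a 1.6-fold lower number from compound 1 to compound 2 (0.19 log units; within the scatter). Compound 2 thus carries the lower of the two numbers, but nothing separates it from compound 1 beyond the usual spread.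

Compound 3 `COc1ccc(-c2nn(-c3ccccc3)cc2C(=O)Nc2nc3ccc(C)cc3s2)cc1` is the next member. It differs from compound 2 by methyl in place of hydrogen on an aromatic carbon, on an aromatic carbon of a six-membered aromatic ring of carbon only, part of a fused system of two rings; cut one bond further out, the change reads 1,3-benzothiazol-2-yl to 6-methyl-1,3-benzothiazol-2-yl. For the measured compounds named here, no measured step touches this ring. Going by the values given here, the only step, from compound 1 to compound 2, is a substituent change on a different aromatic ring and stayed within the scatter. On that basis no step beyond the scatter is expected in this assay, so for compound 3 the expected step is a 1.1-fold lower number from compound 2 to compound 3 (0.05 log units; within the scatter). Compound 3 is therefore estimated at 6000 nM, with a range from 2500 nM to 15000 nM.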

Compound 3, half-maximal inhibitory concentration: 15900 nM
The estimate for compound 3 lay 2.7-fold (0.42 log units) below the measured number; the measured number lies above the stated range.
By their numbers in this assay, from the lowest: compounds 2, 1 and 3 (each within the scatter of the next, the first and the last beyond it).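

In this assay this position responds to a small change: methyl in place of hydrogen on an aromatic carbon of the fused system, one added heavy atom, gives a 2.4-fold higher number from compound 2 to compound 3 (0.38 log units; beyond the scatter), a modest step towards weaker inhibition. For the compounds shown here, the only earlier step, the methoxy change on a different aromatic ring, was a 1.6-fold lower number from compound 1 to compound 2 (0.19 log units; within the scatter), so the 6-methyl-1,3-benzothiazol-2-yl change is the first to go beyond the scatter, and it shows that the benzothiazol-2-yl group cannot be assumed to tolerate substitution here. Nothing available accounts for this step, so it stands as an observation only.

Open, from the compounds shown here alone, is whether the step belongs to methyl itself or to any group on this carbon: a fluorine, a methoxy, an amine or a carboxylic acid at the same place would separate those readings, and a longer chain such as ethyl would show whether the number keeps rising with size. Also open, going by these compounds, is whether methyl on the other carbons of this ring gives the same step, and whether the step holds on the core of compound 1, without the methoxy group.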